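The source may hold more compounds than are shown below. What is called first, only, known or untested is meant among the compounds shown, and "the series" means these compounds.

Measured so far:
Compound 1 `CCn1c(-c2cnc(C)nc2)nc2c(N[C@H]3CCN(C(=O)C4CCC4)C3)ncnc21` gives 1.2 in a physicochemical assay for lipophilicity, read by HPLC; on this read-out higher numbers stand for higher lipophilicity and lower numbers for lower lipophilicity.
Compound 2 `CCC(=O)N1CC[C@H](Oc2ncnc3c2nc(-c2cnc(C)nc2)n3CC)C1` gives 0.8 in this assay.
Compound 3 `CCn1c(-c2ccc(C(F)(F)F)nc2)nc2c(O[C@H]3CCN(C(=O)c4cocn4)C3)ncnc21` gives 2 in this assay.

Of these three, compound 3 stands highest. Its gap to compound 1, the nearest of the other two, lies beyond the usual scatter of this kind of measurement, and its gap to compound 2, the furthest, is larger still. Compound 3 therefore sets the upper mark of the set, and the next compound starts from it.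

Compound 4 `CCn1c(-c2ccc(C(F)(F)F)nc2)nc2c(O[C@H]3CCN(C(=O)N4CC(OC)C4)C3)ncnc21` has not yet been measured. It keeps everything of compound 3 except one group: 3-methoxyazetidin-1-yl in place of 1,3-oxazol-4-yl on a carbonyl carbon. Cut one bond further out, the same exchange reads as (1,3-oxazol-4-yl)carbonyl giving way to (3-methoxyazetidin-1-yl)carbonyl, on a carbonyl carbon whose other neighbour is an amide-type nitrogen in a ring.

Among the measured compounds shown here, no pair among the measured compounds shows this exact exchange, so the size of the shift has to be estimated rather than read off. A small downward step is expected, not far from the scatter, as a number 0.20 log units lower from compound 3 to compound 4 (within the scatter). Compound 4 is expected to give about 1.8 in this assay, with a range from 1.3 to 2.3.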

Compound 4, distribution coefficient: 2.1
Compound 4: the middle estimate sits 0.30 log units below what was measured, within the range that was stated.
By their numbers in this assay, from the lowest: compound 2; then compound 1; then compounds 3 and 4 (each within the scatter of the next).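

In this assay, putting 3-methoxyazetidin-1-yl in place of 1,3-oxazol-4-yl on the carbonyl carbon gives a number 0.10 log units higher from compound 3 to compound 4 (within the scatter) and so leaves the two compounds indistinguishable on this read-out. Among the compounds shown here, this is the first pair in the set that differs in only one place, so it is the first time a single change can be read without other differences in the structures clouding the comparison: here, a five-membered aromatic ring with 2 hetero atoms gives way to a four-membered non-aromatic ring with 1 hetero atom and no measurable shift follows. Nothing shown here offers an explanation for why these two groups read alike.

The compounds shown leave open whether this exchange would read the same way on the other compounds, since compound 1 and compound 2 differ from compound 3 in more than one place and neither forms a single-change pair with it. They also leave open how far this position tolerates other groups on the same carbonyl carbon, such as a morpholin-4-yl ring, a carboxylic acid or a longer alkyl chain.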